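Aryl urea series: fluoro in place of acetyl

A few compounds are considered here, and "the series" means these few. Any claim that something is new, unique, unknown or untested is made for them only; others in the source may bear on it.

Three compounds have been measured in an ADME assay on the whole organism with Oryza sativa as the target, tested at 0.1 uM; on this read-out lower numbers stand for a stronger effect and higher numbers for a weaker effect at the one concentration tested:

compound 1 `CCc1ccccc1NC(=O)N[C@H](C)c1ccccc1` gives 101%
compound 2 `C[C@@H](NC(=O)Nc1ccccc1C(F)(F)F)c1ccccc1` gives 99%
compound 3 `CC(=O)c1ccccc1NC(=O)N[C@H](C)c1ccccc1` gives 96%

Compound 3 carries the lowest of the three numbers, yet nothing separates it from the others: the step of a number 5 percentage points lower from compound 1 to compound 3 (within the scatter) and the step of a number 3 percentage points lower from compound 2 to compound 3 (within the scatter) both sit within the scatter, as does a number 2 percentage points lower from compound 1 to compound 2 (within the scatter). Across ethyl, trifluoromethyl and acetyl at this position the read-out has not moved.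

The next compound, compound 4 `C[C@@H](NC(=O)Nc1ccccc1F)c1ccccc1`, continues this exchange on the same carbon. Compared with compound 3 the difference is fluoro in place of acetyl on an aromatic carbon.

All three measured steps bear on this change, since each swaps one group for another at this aromatic carbon, and each stayed within the scatter. Three different groups, spanning ethyl, trifluoromethyl and acetyl, left the number flat near the top of the scale. Fluoro is a fourth group at the same place; no step beyond the scatter is expected in this assay, in either direction.

Compound 4 is therefore estimated at 99%, within 92% to 106%, so that the expected step of a number 3 percentage points higher from compound 3 to compound 4 (within the scatter) lies within the scatter.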

Compound 4, a percentage reported as activity, at one concentration (the size of the read-out at that concentration, not a potency): 97%
The estimate for compound 4 lay 2 percentage points above the measured number; measured number inside the range.
By their numbers in this assay, from the lowest: compounds 3, 4, 2 and 1 (each within the scatter of the next).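

In this assay, fluoro brings 1 heavy atom where acetyl has 3 heavy atoms, and it lacks the hydrogen-bond acceptor and the double bond of acetyl, yet the result is a number 1 percentage points higher from compound 3 to compound 4 (within the scatter). The comparisons with the other two groups give the same picture, with a number 2 percentage points lower from compound 2 to compound 4 (within the scatter) and a number 4 percentage points lower from compound 1 to compound 4 (within the scatter), so four groups on this aromatic carbon now stand within the scatter of one another, and none of compounds 1 to 4 goes against this. This extends the flat picture to a much smaller group with no acceptor, although nothing at hand accounts for the lack of response at this position.

The compounds shown leave open whether an amine, a carboxylic acid or a longer chain on this aromatic carbon would give a step beyond the scatter, and whether a change elsewhere on the shared core would do so. Going by these compounds, with all four numbers near the top of the scale at the one concentration tested, it also remains open whether any compound of this series has a real effect in this assay.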